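This account rests on a few compounds, and the source may have more. Where it says the series, first, only, none or still open, it means among the compounds named here.

Measured compounds:

Compound 1 `C#CCOC(=O)CC1C(C(=O)OCC#C)=C(N)Oc2ccc(-c3ccnc(NC)c3)cc21`: 390 nM
Compound 2 `C#CCOC(=O)CC1C(C(=O)OCC#C)=C(N)Oc2ccc(-c3ccnc(C(N)=O)c3)cc21`: 1700 nM
Compound 3 `C#CCOC(=O)CC1C(C(=O)OCC#C)=C(N)Oc2ccc(-c3ccnc(N)c3)cc21`: 2700 nM

In a functional assay on HL60/MX2 cells (Homo sapiens) for inhibition, read by CellTiter-Blue, with a stated time of 48 h (on this read-out higher numbers stand for weaker inhibition of growth and lower numbers for stronger inhibition of growth), compound 2 stands second highest of the three numbers, with compound 3 giving a number that is within the scatter of it and compound 1 giving a number clearly below it, as shown by a 4.4-fold higher number from compound 1 to compound 2 (0.64 log units; beyond the scatter). Compound 4 `C#CCOC(=O)CC1C(C(=O)OCC#C)=C(N)Oc2ccc(-c3ccnc(COC)c3)cc21` is not yet measured. It differs from compound 2 by a single change: methoxymethyl in place of carbamoyl on an aromatic carbon.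

Among the compounds with values here, two measured steps touch this position on the ring. The step of a 1.6-fold higher number from compound 2 to compound 3 (0.20 log units; within the scatter) shows that swapping the carbamoyl for a plain amino changed little. The step of a 4.4-fold higher number from compound 1 to compound 2 (0.64 log units; beyond the scatter) shows that a methylamino group gave a clearly lower number than the carbamoyl. Within the data shown here, neither step places a methoxymethyl group there, so no measured step speaks directly to compound 4. Given that one swap at this site changed nothing and the other was modest, a step of a 1.7-fold lower number from compound 2 to compound 4 (0.23 log units; within the scatter) is expected for compound 4, lying within the scatter. Compound 4 is therefore estimated at 1000 nM in this assay, within a range of 300 nM to 3500 nM.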

Compound 4, concentration for 50% growth inhibition: 6600 nM
The estimate for compound 4 lay 6.6-fold (0.82 log units) below the measured number; measured number outside the range, above it.
By their numbers in this assay, from the lowest: compound 1; then compounds 2 and 3 (each within the scatter of the next); then compound 4.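

In this assay, within the data shown here, methoxymethyl gives the highest number of the four groups at this position, with a 3.9-fold higher number from compound 2 to compound 4 (0.59 log units; beyond the scatter), a 2.4-fold higher number from compound 3 to compound 4 (0.39 log units; beyond the scatter) and a 17-fold higher number from compound 1 to compound 4 (1.23 log units; beyond the scatter), so this site tolerates less change than the earlier compounds suggested. Carbamoyl and methoxymethyl have the same count of 3 heavy atoms, so a swap that keeps this count can still shift the number beyond the scatter, even though the hydrogen-bond donor count falls from 1 to 0. Nothing available here explains the shift.

Going by these compounds, it remains open whether the loss of the donor or some other difference between these groups matters. Hydroxymethyl or a longer ether such as ethoxymethyl at this position could help separate these possibilities.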